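Working notes on cytotoxicity across three analogues

A few compounds are considered here, and "the series" means these few. Any claim that something is new, unique, unknown or untested is made for them only; others in the source may bear on it.

Measured so far:
compound 1, `CCCSc1nc(N)nc2c1ncn2/C=C1/C[C@@H]1CO`, giving 283000 nM in a functional assay on HFF cells (Homo sapiens) for cytotoxicity; on this read-out higher numbers stand for lower toxicity in this test and lower numbers for higher toxicity in this test
compound 2, `CCCCCSc1nc(N)nc2c1ncn2/C=C1/C[C@@H]1CO`, giving 215000 nM in this assay

Compound 1 has the highest of the two numbers; its nearest neighbour is compound 2, with a 1.3-fold lower number from compound 1 to compound 2 (0.12 log units; within the scatter), a step within the scatter. Compound 3 `Nc1nc(NC2CC2)c2ncn(/C=C3/C[C@@H]3CO)c2n1` differs from compound 1 by cyclopropylamino in place of propylsulfanyl on an aromatic carbon. Among the measured compounds shown here, the only measured step, a 1.3-fold lower number from compound 1 to compound 2 (0.12 log units; within the scatter), changes the chain alone; no measured step touches the group that leaves or the group that enters, so nothing here anchors a change beyond the scatter. Near the value of compound 1, compound 3 is expected at 250000 nM, within 100000 nM to 600000 nM, that is a 1.1-fold lower number from compound 1 to compound 3 (0.05 log units; within the scatter).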

Compound 3, half-maximal cytotoxic concentration: 213000 nM
Estimate against measurement, compound 3: 1.2-fold (0.07 log units) above; low and high end bracket the measured number.
By their numbers in this assay, from the lowest: compounds 3, 2 and 1 (each within the scatter of the next).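

Earlier compounds varied only the chain on sulfur; here the whole group on the aromatic carbon is exchanged. In this assay, cyclopropylamino in place of propylsulfanyl gives a 1.3-fold lower number from compound 1 to compound 3 (0.12 log units; within the scatter), and in place of pentylsulfanyl gives a 1.0-fold lower number from compound 2 to compound 3 (0.00 log units; within the scatter), so the sulfur-linked chain gives way to a nitrogen-linked three-membered ring with a hydrogen-bond donor, and both steps stay within the scatter. Nothing measured bears on an explanation for this result. Still open, as far as these compounds go, is whether a morpholine or a carboxylic acid on this aromatic carbon would give a step beyond the scatter in this assay.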